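Amine acylation on the neopentyl series: notes toward compound 4

The source may hold more compounds than are shown below. What is called first, only, known or untested is meant among the compounds shown, and "the series" means these compounds.

In an assay on CHO cells for displacement of a labelled ligand from adenosine receptor A3 (Homo sapiens) (on this read-out higher numbers stand for weaker inhibition and lower numbers for stronger inhibition), compound 2 `CCOC(=O)c1nc(N)nc2nn(CC(C)(C)C)cc12` gives 10400 nM. Compound 1 `CC(C)n1cc2c(C(N)=O)nc(N)nc2n1` sits in this assay at > 100000 nM, which is a limit of the assay and not a number. Compound 3 `CCOC(=O)c1nc(NC(=O)c2ccccc2)nc2nn(C(C)C)cc12` gives 8600 nM in this assay. Of the two numbers shown, compound 2 carries the higher one, but its gap to compound 3 lies within the scatter, so the two read as equivalent. For the measured compounds named here, compound 3 differs from compound 2 in more than one place, so no single step between measured compounds is available.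

Compound 4 `CCOC(=O)c1nc(NC(=O)c2ccc(F)cc2)nc2nn(CC(C)(C)C)cc12` arises from compound 2 by (4-fluorophenyl)carbonyl in place of hydrogen on a nitrogen on an aromatic ring. Going by the values given here, no measured step of this kind exists; the nearest point of comparison is compound 3, whose value 8600 nM stands at the same level as compound 2. A modest move toward a lower number is expected, not clearly beyond the scatter. Compound 4 is expected at 5000 nM, with a range from 1500 nM to 16000 nM. The expected step of a 2.1-fold lower number from compound 2 to compound 4 (0.32 log units; beyond the scatter) is therefore small and toward stronger inhibition. The chance that only a limit is reported is small.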

Compound 4, inhibition constant: 4300 nM
Compound 4: the middle estimate sits 1.2-fold (0.07 log units) above what was measured; the range from low to high includes it.
By their numbers in this assay, from the lowest: compounds 4, 3 and 2 (each within the scatter of the next, the first and the last beyond it). At a limit, above all of these: compound 1.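

In this assay, for the compounds shown here, (4-fluorophenyl)carbonyl in place of hydrogen on a nitrogen on an aromatic ring gives a 2.4-fold lower number from compound 2 to compound 4 (0.38 log units; beyond the scatter), the first step that can be read at a single place. The nitrogen thus carries this acyl group with a modest move toward stronger inhibition, something compound 3 could not show, as it differs from compound 2 in more than one place. Nothing in the data at hand bears on why this step occurs.

Open, as far as these compounds go, is whether the step belongs to the carbonyl, the aromatic ring or the fluorine, and an acetyl group or an unsubstituted benzoyl group on the neopentyl compound would separate these. Also open, from the compounds shown here alone, is whether the same acylation holds when a carboxylic acid replaces the ethyl ester.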